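The source may report more compounds than this note shows. Statements on the series, on what has been measured and on what is new or still open speak of the compounds shown alone.

Compound 1 `CCCC(=O)C1=C(C)NC(=O)NC1c1ccoc1` gives 22% in an assay on membranes from HEK293 cells for displacement of a labelled ligand from adenosine receptor A2b (Homo sapiens), read by scintillation counting, with a stated time of 30 min, tested at 1 uM; a higher number here means more inhibition at the concentration tested (going by the name of the read-out), a lower number less inhibition.
Compound 2 `CC1=C(C(=O)NC(C)C)C(c2ccco2)NC(=O)N1` gives 2% in this assay.
Compound 3 `CC1=C(C(N)=O)C(c2ccoc2)NC(=O)N1` gives 6% in this assay.

Compound 3 stands second of the three, its value within the scatter of that of compound 2, while a number 16 percentage points lower from compound 1 to compound 3 (beyond the scatter) marks a modest fall beyond the scatter. Compound 4 `CC1=C(C(=O)NC(C)C)C(c2ccoc2)NC(=O)N1` is reached from compound 3 by isopropyl in place of hydrogen on an amide-type nitrogen. Going by the values given here, no measured step covers this change. Compound 2 carries the same isopropylcarbamoyl group on a different furan and gives a low value close to that of compound 3, so a step of no size beyond the scatter is expected: compound 4 is estimated at 5% (range 0% to 18%), a step of a number 1 percentage points lower from compound 3 to compound 4 (within the scatter).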

Compound 4, a percentage reported as inhibition, at one concentration (the size of the read-out at that concentration, not a potency): 3%
Compound 4: middle estimate off by 2 percentage points, on the high side; the measured number falls inside the stated range.
By their numbers in this assay, from the lowest: compounds 2, 4 and 3 (each within the scatter of the next); then compound 1.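

In this assay, isopropyl on the amide-type nitrogen makes no difference that can be told from the scatter, giving a number 3 percentage points lower from compound 3 to compound 4 (within the scatter), and the direct comparison of furan-3-yl with furan-2-yl on a saturated ring carbon shows the same, giving a number 1 percentage points higher from compound 2 to compound 4 (within the scatter). Isopropylamino on the carbonyl carbon stays clearly short of propyl there, giving a number 19 percentage points lower from compound 1 to compound 4 (beyond the scatter). No evidence bears on why these steps come out as they do. From the compounds shown here alone, it remains open whether a longer chain such as butyl or a cyclic amine such as piperidine in that place on the carbonyl carbon would reach or pass compound 1.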